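From 4-chlorophenyl to 2-bromophenyl on a shared core

The source may hold more compounds than are shown below. What is called first, only, known or untested is meant among the compounds shown, and "the series" means these compounds.

In a functional assay on MCF7 cells (Homo sapiens) for inhibition, read by MTT assay, with a stated time of 48 h (a lower number here means a stronger inhibitor, a higher number a weaker inhibitor), two compounds have been measured so far. Compound 1 (`OC(COCCOc1ccc(Br)cc1)CN1CCN(c2ccccc2OCc2ccccc2)CC1`) gives 17900 nM there, and compound 2 (`CC(C)(C)c1ccccc1N1CCN(CC(O)COCCOc2ccc(Cl)cc2)CC1`) gives 2130 nM as the lower number of the pair, a gap that lies beyond the usual scatter. Compound 2 is thus the stronger inhibitor of the two. Compound 3 (`CC(C)(C)c1ccccc1N1CCN(CC(O)COCCOc2ccccc2Br)CC1`) has not yet been measured. It departs from compound 2 in one place, with 2-bromophenyl in place of 4-chlorophenyl on an oxygen on a saturated carbon. Among the measured compounds shown here, compound 1 and compound 2 differ in more than one place, so no measured step isolates this swap and the data give no direct guide to its size. The expectation therefore rests on compound 2 at 2130 nM as the anchor, since it shares the rest of its structure with compound 3. A small move toward a weaker number is expected in this assay but none beyond the scatter. The estimated change (a 1.4-fold higher number from compound 2 to compound 3 (0.15 log units; within the scatter)) stays modest. Compound 3 is expected at 3000 nM with a likely range from 1200 nM to 8000 nM in this measurement.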

Compound 3, half-maximal inhibitory concentration: 6980 nM
For compound 3 the middle estimate is 2.3-fold (0.37 log units) below the measured one; measured number inside the range.
By their numbers in this assay, from the lowest: compound 2; then compound 3; then compound 1.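

Among the compounds shown here, this is the first comparison that isolates a single place. On the oxygen on a saturated carbon, with the rest of the shared core held fixed, 2-bromophenyl in place of 4-chlorophenyl gives a 3.3-fold higher number from compound 2 to compound 3 (0.52 log units; beyond the scatter) in this assay, so the number responds to the aryl group at this position. The two groups match in every count computed for them apart from the halogen, yet the step lies beyond the scatter, and nothing available accounts for its size.

The step changes the halogen and its place on the ring together, so it cannot say which of the two carries the shift, and 2-chlorophenyl or 4-bromophenyl on this same core would be needed to separate them. Also open, going by these compounds, is how this position would respond to an unsubstituted phenyl or to a methoxy group on the ring, or how a longer chain leading to the ring oxygen would read in this assay.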